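Compound 3 without its ethoxy group

The source may hold more compounds than are shown below. What is called first, only, known or untested is meant among the compounds shown, and "the series" means these compounds.

In a functional assay on SMMC-7721 cells (Homo sapiens) for cytotoxicity, read by MTT assay (a lower number here means a stronger inhibitor, a higher number a weaker inhibitor), compound 1 `C/C=C(\C)C(=O)O[C@@H]1[C@@H]2OC[C@]3(C)[C@H](OC(C)=O)C[C@H](O)[C@@](C)([C@@H]23)[C@H]2C[C@H](OC)O[C@H]3C[C@@H](C4=CCOC4=O)C(C)=C3[C@]12C` gives 50000 nM and compound 2 `C/C=C(\C)C(=O)O[C@@H]1[C@@H]2OC[C@]3(C)[C@H](OC(C)=O)C[C@H](O)[C@@](C)([C@@H]23)[C@H]2C[C@H](O)O[C@H]3C[C@@H](C4=CCOC4=O)C(C)=C3[C@]12C` gives 50000 nM. Compound 3 `C/C=C(\C)C(=O)O[C@@H]1[C@@H]2OC[C@]3(C)[C@H](OC(C)=O)C[C@H](O)[C@@](C)([C@@H]23)[C@H]2C[C@H](OCC)O[C@H]3C[C@@H](C4=CCOC4=O)C(C)=C3[C@]12C` gives > 100000 nM, which is a limit of the assay and not a number. Compound 4 `C/C=C(\C)C(=O)O[C@@H]1[C@@H]2OC[C@]3(C)[C@H](OC(C)=O)C[C@H](O)[C@@](C)([C@@H]23)[C@H]2CCO[C@H]3C[C@@H](C4=CCOC4=O)C(C)=C3[C@]12C` carries hydrogen in place of ethoxy on a saturated ring carbon, next to the ring oxygen: hydrogen in place of ethoxy on a saturated ring carbon. Changes on the oxygen at that carbon gave no change at the digits printed from compound 1 to compound 2 (within the scatter), an at least 2.0-fold higher number from compound 1 to compound 3 (0.30 log units; that floor lies within the scatter) and an at least 2.0-fold higher number from compound 2 to compound 3 (0.30 log units; that floor lies within the scatter), so none shows a step beyond the scatter. Going by the values given here, no measured compound lacks that oxygen. Only a small shift in this assay towards the value of compound 2 at 50000 nM is therefore expected, an estimated at least 2.0-fold lower number from compound 3 to compound 4 (0.30 log units; that floor lies within the scatter). The estimate for compound 4 is 50000 nM, with an expected range of 20000 nM to 100000 nM.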

Compound 4, half-maximal inhibitory concentration: > 100000 nM
Compound 4: no number, only a limit; the forecaster's own chance of this, stated with the estimate: 35%; middle value at least 2.0-fold (0.30 log units) from the limit.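

In this assay compound 4, with no oxygen left on this saturated ring carbon, gives > 100000 nM, a limit and not a number. Hydrogen here gives an at least 2.0-fold higher number from compound 2 to compound 4 (0.30 log units; that floor lies within the scatter) and an at least 2.0-fold higher number from compound 1 to compound 4 (0.30 log units; that floor lies within the scatter), so removing the oxygen shows no step beyond the scatter either. The step between compound 3 and compound 4 cannot be read because both values are limits: the limit of > 100000 nM in this assay, at which 2 of the 4 values shown sit.

On these data alone, whether an amine or a carboxylic acid on this carbon would give a number inside the range of this assay remains open. Also open, as far as these compounds go, is whether any group here produces a step beyond the scatter.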